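This account rests on a few compounds, and the source may have more. Where it says the series, first, only, none or still open, it means among the compounds named here.

The account concerns three compounds built on one shared core. Compound 1, `Cc1ccc(-c2nn(-c3ccccc3)cc2-c2nc3ccccc3n2C(=O)c2cccc(C)c2)cc1`, and compound 2, `Cc1ccc(C(=O)n2c(-c3cn(-c4ccccc4)nc3-c3ccc(C(F)(F)F)cc3)nc3ccccc32)cn1`, have been measured; compound 3, `Cc1ccc(-c2nn(-c3ccccc3)cc2-c2nc3ccccc3n2C(=O)c2ccc(C)nc2)cc1`, has not. In an ADME assay on HEK-293T cells (Homo sapiens) for cytotoxicity, read by MTT assay, with a stated time of 24 h (on this read-out higher numbers stand for lower toxicity in this test and lower numbers for higher toxicity in this test), compound 1 gives 195000 nM. In this assay, among the measured compounds shown here, compound 2 gives 153000 nM; this is one of only two numbers known, and it sits within the usual scatter of the number for compound 1, so no order between the two can be read from them.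

Compound 3 arises from compound 2 by a single change: methyl in place of trifluoromethyl on an aromatic carbon. For the measured compounds named here, no pair of measured compounds that differs in exactly one place is available, so the size of this kind of step cannot be drawn from the data. Compound 1 does carry the methyl group on the same ring, and its value, 195000 nM, lies close to that of compound 2; on that basis no step beyond the scatter is expected, and the estimated step is a 1.2-fold higher number from compound 2 to compound 3 (0.07 log units; within the scatter). Compound 3 is therefore expected to give 180000 nM, with a range from 90000 nM to 360000 nM.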

Compound 3, half-maximal cytotoxic concentration: 145000 nM
Compound 3: middle estimate off by 1.2-fold (0.09 log units), on the high side; the range from low to high includes it.
By their numbers in this assay, from the lowest: compounds 3, 2 and 1 (each within the scatter of the next).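

In this assay, among the compounds shown here, the exchange of trifluoromethyl for methyl on this aromatic carbon, para to a large group, gives a 1.1-fold lower number from compound 2 to compound 3 (0.02 log units; within the scatter) and so supplies the first step at this position that can be read from a single change; it lies within the scatter, and no separation between the two groups can be claimed in this test. The second change, on the carbonyl carbon, puts 6-methylpyridin-3-yl in place of 3-methylphenyl and gives a 1.3-fold lower number from compound 1 to compound 3 (0.13 log units; within the scatter) and this step also lies within the scatter, so neither of the two places touched so far shows a measurable effect on the read-out. Nothing available accounts for the size of these steps.

The compounds shown leave open whether this position tolerates every group equally, since only trifluoromethyl and methyl have been seen there, and an amine, a carboxylic acid or a longer chain on the same carbon could behave differently. They also leave open whether a step beyond the scatter can be found anywhere on the shared core, as all three numbers remain within the scatter of one another.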